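Cytotoxicity of a Bromophenyl Amide Beside Its Furan Parent

The source may hold more compounds than are shown below. What is called first, only, known or untested is meant among the compounds shown, and "the series" means these compounds.

Compound 1, `CN(C)c1cc2[nH]c(C3CCCCC3)nc2cc1NC(=O)c1ccco1`, was tested in an ADME assay on Vero cells (Chlorocebus sabaeus) for cytotoxicity, read by resazurin assay, with a stated time of 3 days; on this read-out higher numbers stand for weaker inhibition and lower numbers for stronger inhibition. In this assay compound 1 gives > 100 ug/mL, which is a limit of the assay and not a number. Two further compounds were run in the same assay. Compound 2, `CCCCOC(=O)Nc1cc2nc(C3CCCCC3)[nH]c2cc1N(C)CCN(C)C`, gives > 100 ug/mL in this assay, again a limit. Compound 3, `O=C(Nc1cc2nc(C3CCCCC3)[nH]c2cc1N1CCCC1)c1ccccc1`, gives > 100 ug/mL in this assay, also a limit. Compound 1 therefore stands exactly where every value shown stands, namely at the limit of > 100 ug/mL in this assay, at which 3 of the 3 values shown sit. Going by the values given here, no step between the measured compounds can be drawn. None of the three differs from another in one place only, and the three values show nothing beyond the shared limit.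

Compound 4, `CN(C)c1cc2[nH]c(C3CCCCC3)nc2cc1NC(=O)c1cccc(Br)c1`, is still to be measured in this assay. It differs from compound 1 in one place: 3-bromophenyl in place of furan-2-yl on a carbonyl carbon. Among the compounds with values here, nothing in the measured set connects this change to a shift in cytotoxicity, and the only value shown for compound 1 is the limit. Compound 4 is therefore expected to give about 100 ug/mL in this assay, with a range from 50 ug/mL to 200 ug/mL. The expected step is a number no higher from compound 1 to compound 4 (the limit leaves the size open), that is, none beyond the usual scatter, most likely ending again at the limit.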

Compound 4, half-maximal inhibitory concentration: > 100 ug/mL
Compound 4: no number, only a limit; the forecaster's own chance of this, stated with the estimate: 85%; the middle value lies on the limit itself.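

In this assay compound 4 gives > 100 ug/mL, which is a limit of the assay and not a number. Compound 1 also stands at a limit, so no step can be read from compound 1 to compound 4. The compounds shown leave open whether 3-bromophenyl in place of furan-2-yl on a carbonyl carbon changes cytotoxicity at all.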